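A few compounds are considered here, and "the series" means these few. Any claim that something is new, unique, unknown or untested is made for them only; others in the source may bear on it.

In an in vitro ADME assay on microsomes (Homo sapiens) for metabolic stability (a higher number here means faster removal of the compound, a lower number slower removal), compound 1 `O=C(CN(C(=O)c1ccc(-c2ccccn2)cc1)C1CCCCC1)Nc1cc(F)cc(F)c1` gives 5.2 mL.min-1.g-1. Compound 2 `O=C(CN(CC1CC1)C(=O)c1ccc(-c2ccccn2)cc1)Nc1cc(F)cc(F)c1` gives < 0.5 mL.min-1.g-1, which is a limit of the assay and not a number, and so it stands at the limit of < 0.5 mL.min-1.g-1 in this assay, at which 1 of the 2 values shown sits. Compound 3 `CCC(COC)N(CC(=O)Nc1cc(F)cc(F)c1)C(=O)c1ccc(-c2ccccn2)cc1` has 1-(methoxymethyl)propyl in place of cyclopropylmethyl on an amide-type nitrogen. Going by the values given here, only one measured step bears on this nitrogen: an at least 10-fold lower number from compound 1 to compound 2 (1.01 log units; beyond the scatter), which is large and beyond the scatter. It shows how far a change here can move the number in this assay, but it does not cover the entering group. A moderate rise is expected, with an estimated at least 5.0-fold higher number from compound 2 to compound 3 (0.69 log units; beyond the scatter). Compound 3 is expected at 2.5 mL.min-1.g-1, with an estimated range of 0.7 mL.min-1.g-1 to 8 mL.min-1.g-1.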

Compound 3, intrinsic clearance in microsomes: 9.6 mL.min-1.g-1
The estimate for compound 3 lay 3.8-fold (0.58 log units) below the measured number, outside the stated range (above it).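

In this assay this amide-type nitrogen shows a second large move, now in the opposite direction, with an at least 19-fold higher number from compound 2 to compound 3 (1.28 log units; beyond the scatter). Compound 2 holds a limit of the assay and not a number: the limit of < 0.5 mL.min-1.g-1 in this assay, at which 1 of the 3 values shown sits. Replacing cyclohexyl with 1-(methoxymethyl)propyl, which has no ring and carries a hydrogen-bond acceptor, gives a 1.8-fold higher number from compound 1 to compound 3 (0.27 log units; within the scatter), so among these three groups only cyclopropylmethyl goes with the low reading.

From the compounds shown here alone, whether that low reading follows the three-membered ring or the rest of the group stays open. A 2-methoxyethyl or an n-butyl chain on this nitrogen would bear on that question.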